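Removing a trifluoromethyl from a chlorophenyl sulfonamide

The source may report more compounds than this note shows. Statements on the series, on what has been measured and on what is new or still open speak of the compounds shown alone.

For the measured compounds named here, compound 2 `O=S(=O)(NCCCNCc1ccc(Cl)c(C(F)(F)F)c1)c1cc(C(F)(F)F)cc(C(F)(F)F)c1` is one of two compounds measured in a functional assay on PANC-1 cells (Homo sapiens) for inhibition, read by MTT assay, with a stated time of 72 h (on this read-out lower numbers stand for stronger inhibition of growth and higher numbers for weaker inhibition of growth), where compound 2 gives 10000 nM. Compound 1 `O=S(=O)(NCCCNCc1ccccc1Cl)c1cc(C(F)(F)F)cc(C(F)(F)F)c1` gives 15000 nM in this assay. Going by the values given here, the only step known is a 1.5-fold lower number from compound 1 to compound 2 (0.18 log units; within the scatter), and its two values lie within the scatter of each other. Compound 3 `O=S(=O)(NCCCNCc1ccc(Cl)cc1)c1cc(C(F)(F)F)cc(C(F)(F)F)c1` differs from compound 2 by hydrogen in place of trifluoromethyl on an aromatic carbon, undoing part of that earlier change. Among the compounds with values here, since the one known step was within the scatter, compound 3 is expected to give 12000 nM, between 6000 nM and 25000 nM, so a 1.2-fold higher number from compound 2 to compound 3 (0.08 log units; within the scatter) is expected to stay within the scatter.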

Compound 3, concentration for 50% growth inhibition: 4900 nM
For compound 3 the middle estimate is 2.4-fold (0.39 log units) above the measured one; the whole stated range lies above it.
By their numbers in this assay, from the lowest: compound 3; then compounds 2 and 1 (each within the scatter of the next).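

Taking the trifluoromethyl off this aromatic carbon, ortho to a chloro group, gives a 2.0-fold lower number from compound 2 to compound 3 (0.31 log units; beyond the scatter) in this assay, the first step in the set to clear the scatter, so hydrogen here goes with stronger inhibition of growth. The change from 2-chlorophenyl to 4-chlorophenyl gives a 3.1-fold lower number from compound 1 to compound 3 (0.49 log units; beyond the scatter), which leaves compound 3 the strongest of the three. Nothing available explains why either step occurs. The compounds shown leave open whether a methyl, a methoxy or a fluoro group on this carbon would give a number closer to compound 2 or to compound 3.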